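Benzyl on the carboxamide nitrogen of compound 1

This account rests on a few compounds, and the source may have more. Where it says the series, first, only, none or still open, it means among the compounds named here.

Compound 1 `NC(=O)c1ccc2c(ccn2-c2ccc(NC(=O)c3cccc(C(F)(F)F)c3)cc2)n1` carries a primary carboxamide on the shared core and a 3-(trifluoromethyl)phenyl amide on the far side. In a functional assay on A375P cells (Homo sapiens) for cytotoxicity, read by MTT assay (on this read-out higher numbers stand for weaker inhibition and lower numbers for stronger inhibition), compound 1 gives > 10000 nM, which is a limit of the assay rather than a number (the limit of > 10000 nM in this assay, at which 1 of the 3 values shown sits). Compound 2 `NC(=O)c1ccc2c(ccn2-c2ccc(NC(=O)Nc3ccc(Cl)c(Cl)c3)cc2)n1` gives 3200 nM and compound 3 `NC(=O)c1ccc2c(ccn2-c2ccc(NC(=O)Nc3cccc(Cl)c3Cl)cc2)n1` gives 4600 nM in this assay. The measured steps of an at least 3.1-fold lower number from compound 1 to compound 2 (0.49 log units; beyond the scatter) and an at least 2.1-fold lower number from compound 1 to compound 3 (0.33 log units; beyond the scatter) both alter the aryl on the carbonyl carbon, and a 1.4-fold higher number from compound 2 to compound 3 (0.16 log units; within the scatter) stays on that side too; none touches the carboxamide. Compound 4 `O=C(Nc1ccc(-n2ccc3nc(C(=O)NCc4ccccc4)ccc32)cc1)c1cccc(C(F)(F)F)c1` differs from compound 1 by benzyl in place of hydrogen on an amide-type nitrogen. No measured step bears on this change, so no direction beyond the scatter can be expected from the numbers shown. Compound 4 is therefore estimated at 15000 nM (range 3000 nM to 60000 nM), the expected step that the limit leaves unreadable from compound 1 to compound 4 being small and uncertain.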

Compound 4, half-maximal inhibitory concentration: 3000 nM
Compound 4: middle estimate off by 5.0-fold (0.70 log units), on the high side; the measured number falls inside the stated range.
By their numbers in this assay, from the lowest: compounds 4, 2 and 3 (each within the scatter of the next). At a limit, above all of these: compound 1.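

The carboxamide nitrogen now has a reading: in this assay benzyl in place of hydrogen gives an at least 3.3-fold lower number from compound 1 to compound 4 (0.52 log units; beyond the scatter) and this lies beyond the scatter. The earlier steps shown here all stayed on the carbonyl-carbon side, whereas here a change on the carboxamide alone moves the number with the 3-(trifluoromethyl)phenyl amide kept. Compound 1 stands at a limit of the assay, so the full size of this step stays unread: the limit of > 10000 nM in this assay, at which 1 of the 4 values shown sits.

Open, on these data alone, is whether the aromatic ring of benzyl is needed, which methyl or a longer alkyl chain on this nitrogen would test. Also open, as far as these compounds go, is whether benzyl has a similar effect on the ureas compound 2 and compound 3.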